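The source may report more compounds than this note shows. Statements on the series, on what has been measured and on what is new or still open speak of the compounds shown alone.

Of the compounds shown here, two have been measured so far in a functional assay on HeLa cells (Homo sapiens) for inhibition, read by CCK-8 assay, with a stated time of 72 h; on this read-out higher numbers stand for weaker inhibition and lower numbers for stronger inhibition. Compound 1 `O=C(/C=C/c1cccnc1)NCCCCCCc1cccc(S(=O)(=O)Nc2ccccc2)c1` gives 30.4 nM there, and compound 2 `Cc1cccc(NS(=O)(=O)c2cccc(CCCCCCNC(=O)/C=C/c3cccnc3)c2)c1` gives 65.8 nM as the higher of the two numbers, which makes it the weaker inhibitor of the pair. The next compound, compound 3 `Cc1ccc(C)c(NS(=O)(=O)c2cccc(CCCCCCNC(=O)/C=C/c3cccnc3)c2)c1`, differs from compound 2 in one place: methyl in place of hydrogen on an aromatic carbon. Put simply, a methyl takes the place of a hydrogen on an aromatic carbon, so 3-methylphenyl becomes 2,5-dimethylphenyl. Within the data shown here, only one measured step bears on this, the same swap of hydrogen for methyl: a 2.2-fold higher number from compound 1 to compound 2 (0.34 log units; beyond the scatter) is a modest change, but one beyond the scatter. That step did not put a methyl ortho to a large group, and a single step is thin evidence, so the range has to stay wide. A similar modest rise in this assay is therefore expected, with a 1.5-fold higher number from compound 2 to compound 3 (0.18 log units; within the scatter) as the estimated step. For compound 3 the expected value is 100 nM, with an estimated range from 35 nM to 260 nM.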

Compound 3, half-maximal inhibitory concentration: 22.6 nM
Compound 3: the middle estimate sits 4.4-fold (0.65 log units) above what was measured; the measured number lies below the stated range.
By their numbers in this assay, from the lowest: compounds 3 and 1 (each within the scatter of the next); then compound 2.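

In this assay the same swap of hydrogen for methyl on an aromatic carbon now runs in both directions: the earlier step was a 2.2-fold higher number from compound 1 to compound 2 (0.34 log units; beyond the scatter) and the new one is a 2.9-fold lower number from compound 2 to compound 3 (0.46 log units; beyond the scatter), each beyond the scatter, so among these compounds the outcome depends on where the methyl lands, here ortho to a large group and para to a methyl group. The 2,5-dimethylphenyl group also brings the number back into line with the plain phenyl of compound 1, with a 1.3-fold lower number from compound 1 to compound 3 (0.13 log units; within the scatter) as the step, so compound 1 and compound 3 cannot be told apart in this assay even though they differ by two methyl groups. Nothing available explains why this place on the ring behaves differently from the earlier one.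

Still open, going by these compounds, is whether the methyl ortho to a large group would have the same effect on a ring without the other methyl, since here the two arrive together. It is also unknown whether a larger or different group in that place, such as ethyl, chlorine or methoxy, would follow the methyl or break from it.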